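The source may report more compounds than this note shows. Statements on the series, on what has been measured and on what is new or still open speak of the compounds shown alone.

In a functional assay (QGY7701 cells, Homo sapiens) for inhibition, read by MTT assay, with a stated time of 48 h (a lower number here means a stronger inhibitor, a higher number a weaker inhibitor), three compounds built on one shared core have been measured. Compound 1 `COc1ccc2c(=O)c(/C=C/C(=O)Nc3cccc(Cl)c3)coc2c1` carries a 3-chlorophenyl group on an amide-type nitrogen; in this assay compound 1 gives > 100000 nM, which is a limit of the assay and not a number. Compound 2 `COc1ccc2c(=O)c(/C=C/C(=O)NCc3ccccc3)coc2c1` carries a benzyl group in that place, and compound 2 gives > 100000 nM, again a limit. Going by the values given here, compound 3 `COc1ccc2c(=O)c(/C=C/C(=O)NCc3cccc(F)c3)coc2c1` carries a 3-fluorobenzyl group there, and compound 3 gives 28600 nM, the only actual number among the three. The step of an at least 3.4-fold lower number from compound 1 to compound 3 (0.54 log units; beyond the scatter) and the step of an at least 3.4-fold lower number from compound 2 to compound 3 (0.54 log units; beyond the scatter) point the same way, towards a lower number for the 3-fluorobenzyl amide, though their full size stays hidden because the limit of > 100000 nM in this assay, at which 2 of the 3 values shown sit, holds the two starting values. The step that the two limits leave unreadable from compound 1 to compound 2 cannot be read for the same reason.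

Compound 4 `COc1ccc2c(=O)c(/C=C/C(=O)Nc3ccccc3OC)coc2c1` is not yet measured. It differs from compound 3 by 2-methoxyphenyl in place of 3-fluorobenzyl on an amide-type nitrogen. This returns a phenyl-type group to the amide-type nitrogen, as in compound 1, whose value is a limit, and removes the fluorine that marks the step of an at least 3.4-fold lower number from compound 2 to compound 3 (0.54 log units; beyond the scatter). For compound 4 an upward step is therefore expected, a 2.4-fold higher number from compound 3 to compound 4 (0.39 log units; beyond the scatter), with a fair chance that only a limit is reported again. The estimate for compound 4 in this assay is 70000 nM, between 15000 nM and 300000 nM.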

Compound 4, half-maximal inhibitory concentration: 17600 nM
Compound 4: middle estimate off by 4.0-fold (0.60 log units), on the high side; measured number inside the range.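

In this assay, there is an at least 5.6-fold lower number from compound 1 to compound 4 (0.75 log units; beyond the scatter), so a phenyl-type group placed directly on the amide-type nitrogen does not by itself leave a compound at the assay limit; what is attached to that phenyl group can separate a measurable compound from an unmeasurable one. There is also a 1.6-fold lower number from compound 3 to compound 4 (0.21 log units; within the scatter), so 3-fluorobenzyl and 2-methoxyphenyl cannot be told apart here, and a measurable number at this place requires neither the fluorine nor the benzyl group. Compound 4 also stands clear of the plain benzyl amide, with an at least 5.6-fold lower number from compound 2 to compound 4 (0.75 log units; beyond the scatter), but this step and the step from compound 1 show only a minimum size because both start from a limit: the limit of > 100000 nM in this assay, at which 2 of the 4 values shown sit.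

Open, from the compounds shown here alone, is whether a plain phenyl group on the amide-type nitrogen would stay at a limit or give a number, which would show how much the methoxy group contributes. Also open, going by these compounds, is whether an amine or a carboxylic acid on the aromatic ring, or a phenethyl group in place of the benzyl group, would lower the number further.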